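Methyl removal from the saturated ring carbon of the shared core

The source may report more compounds than this note shows. Statements on the series, on what has been measured and on what is new or still open speak of the compounds shown alone.

Of the compounds shown here, two have been measured in an assay on isolated protein for inhibition of Aromatase (Homo sapiens); on this read-out higher numbers stand for weaker inhibition and lower numbers for stronger inhibition. Compound 1 `CN1C(=O)CC(C)(c2ccc(N)cc2)C1=O` gives 10000 nM. Compound 2 `CC1(c2ccc(N)cc2)CC(=O)NC1=O` differs from compound 1 by a hydrogen in place of methyl on an amide-type nitrogen in a ring. In this assay compound 2 gives 10000 nM. The recorded step no change at the digits printed from compound 1 to compound 2 (within the scatter) therefore lies within the scatter, and compound 2 stands level with compound 1 at the digits shown; compound 1 is its only measured neighbour.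

Compound 3 `Nc1ccc(C2CC(=O)NC2=O)cc1` has not yet been measured in this assay. It differs from compound 2 by hydrogen in place of methyl on a saturated ring carbon. For the measured compounds named here, no measured step touches a saturated ring carbon of the shared core; the one step available, no change at the digits printed from compound 1 to compound 2 (within the scatter), concerns the ring nitrogen instead and was flat. With nothing pointing either way, the step of no change at the digits printed from compound 2 to compound 3 (within the scatter) is expected to stay within the scatter, with no direction assigned. As far as these compounds go, for compound 3 the estimate in this assay is 10000 nM, with a range from 4000 nM to 25000 nM, the width reflecting that the change is untested.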

Compound 3, half-maximal inhibitory concentration: 10200 nM
Compound 3: middle estimate off by 1.0-fold (0.01 log units), on the low side; low and high end bracket the measured number.
By their numbers in this assay, from the lowest: compounds 1, 2 and 3 (each within the scatter of the next).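

The saturated ring carbon of the shared core now has a measured step of its own: hydrogen in place of methyl gives a 1.0-fold higher number from compound 2 to compound 3 (0.01 log units; within the scatter) in this assay. The earlier compounds shown here covered only the ring nitrogen, so this reading extends the picture to a second position, and each of the two single steps lies within the scatter. No available evidence bears on this result.

The compounds shown carry only methyl or hydrogen at this ring carbon and at the ring nitrogen, and these two small substituents give no indication of how a longer chain such as propyl, a phenyl ring or a carboxylic acid would read at either position. Also open, as far as these compounds go, is whether the amine on the aromatic ring of the shared core matters in this assay, since every compound here carries it and replacing it with a nitro group or a hydroxyl group is the kind of single change that would test this.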